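Swapping a dichlorophenyl for a nitrophenyl on the enone chain

The source may hold more compounds than are shown below. What is called first, only, known or untested is meant among the compounds shown, and "the series" means these compounds.

Two esters of this series have been tested. Compound 1 `O=C(OC/C(=C\c1ccccc1[N+](=O)[O-])C(=O)c1ccccc1)c1ccccc1` gives 18000 nM in a functional assay on WiDr cells (Homo sapiens) for inhibition, read by sulforhodamine B assay, with a stated time of 48 h (on this read-out higher numbers stand for weaker inhibition of growth and lower numbers for stronger inhibition of growth), while compound 2 `O=C(OC/C(=C/c1ccc(Cl)cc1Cl)C(=O)c1ccccc1)c1ccccc1` gives 8700 nM. Compound 2 thus holds the lower of the two numbers, and its gap to compound 1 lies beyond the scatter of this assay.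

The next compound, compound 3 `O=C(OC/C(=C/c1ccccc1[N+](=O)[O-])C(=O)c1ccccc1)c1ccccc1`, differs from compound 2 by 2-nitrophenyl in place of 2,4-dichlorophenyl on a double-bonded chain carbon bound to a double-bonded chain carbon. Compound 1 carries the same 2-nitrophenyl group, with the other geometry about the double bond, and its value in this assay sits higher than that of compound 2. On that basis the author expects a step from compound 2 to compound 3 of about a 1.7-fold higher number from compound 2 to compound 3 (0.24 log units; within the scatter), towards weaker inhibition of growth. For compound 3 the estimate in this assay is 15000 nM, with a range from 6000 nM to 40000 nM.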

Compound 3, concentration for 50% growth inhibition: 21000 nM
Estimate against measurement, compound 3: 1.4-fold (0.15 log units) below; measured number inside the range.
By their numbers in this assay, from the lowest: compound 2; then compounds 1 and 3 (each within the scatter of the next).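

With the geometry about the double bond kept the same, the change of group can now be read on its own: in this assay, 2-nitrophenyl in place of 2,4-dichlorophenyl on a double-bonded chain carbon bound to a double-bonded chain carbon gives a 2.4-fold higher number from compound 2 to compound 3 (0.38 log units; beyond the scatter), a modest step towards weaker inhibition of growth. The geometry itself makes no difference that can be told in this assay, with a 1.2-fold higher number from compound 1 to compound 3 (0.07 log units; within the scatter). This is a clean reading of geometry for the 2-nitrophenyl group alone: the fact that compounds 1 and 3 differ only in the configuration as drawn

The compounds shown leave open whether the other geometry would matter with 2,4-dichlorophenyl on the chain. They also leave open how an unsubstituted phenyl, or a phenyl carrying an amine or a carboxylic acid, would stand at this position.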